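A Second Trifluoromethyl Group on Compound 2

This account rests on a few compounds, and the source may have more. Where it says the series, first, only, none or still open, it means among the compounds named here.

In a functional assay on MCF7 cells (Homo sapiens) for inhibition, read by MTT assay, with a stated time of 72 h (a higher number here means a weaker inhibitor, a lower number a stronger inhibitor), compound 1 (`COc1cc(NC(C)CCCNC(=O)NNC(=O)Nc2ccc(F)cc2)c2ncccc2c1`) gives 310 nM and compound 2 (`COc1cc(NC(C)CCCNC(=O)NNC(=O)Nc2cccc(C(F)(F)F)c2)c2ncccc2c1`) gives 190 nM. These two values lie within the usual scatter of each other, so neither compound can be ranked above the other. Compound 3 (`COc1cc(NC(C)CCCNC(=O)NNC(=O)Nc2cc(C(F)(F)F)cc(C(F)(F)F)c2)c2ncccc2c1`) has not yet been measured. It differs from compound 2 by trifluoromethyl in place of hydrogen on an aromatic carbon, with trifluoromethyl in place of hydrogen on an aromatic carbon, meta to a trifluoromethyl group. Going by the values given here, only one measured step bears on this change: a 1.6-fold lower number from compound 1 to compound 2 (0.21 log units; within the scatter), where 3-(trifluoromethyl)phenyl stands in place of 4-fluorophenyl. That step stays within the scatter, and it is a different change, so it offers only weak guidance. No step beyond the scatter is therefore expected in this assay. The estimated step is a 1.1-fold lower number from compound 2 to compound 3 (0.05 log units; within the scatter), and its direction is uncertain. For compound 3 the expected value is 170 nM, with an estimated range from 70 nM to 400 nM.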

Compound 3, half-maximal inhibitory concentration: 2400 nM
The estimate for compound 3 lay 14-fold (1.15 log units) below the measured number; the whole stated range lies below it.
By their numbers in this assay, from the lowest: compounds 2 and 1 (each within the scatter of the next); then compound 3.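

In this assay, putting trifluoromethyl in place of hydrogen on an aromatic carbon, meta to a trifluoromethyl group, gives a 13-fold higher number from compound 2 to compound 3 (1.10 log units; beyond the scatter). So this ring position is not free to fill: the earlier exchange of 4-fluorophenyl for 3-(trifluoromethyl)phenyl, a 1.6-fold lower number from compound 1 to compound 2 (0.21 log units; within the scatter), left the number within the scatter and gave no sign of such sensitivity, whereas this single added group makes compound 3 a clearly weaker inhibitor than compound 2. Nothing available explains why this added group has so large an effect.

The compounds shown leave open whether the loss belongs to trifluoromethyl itself or to any group on this carbon. A nitrile or an amine in the same place would help to separate these two readings.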